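Compound 3 to compound 4: chloro in place of methoxy

This account rests on a few compounds, and the source may have more. Where it says the series, first, only, none or still open, it means among the compounds named here.

Values in a functional assay on HCT-116 cells (Homo sapiens) for antiproliferative activity, read by MTT assay, with a stated time of 72 h (on this read-out higher numbers stand for weaker inhibition and lower numbers for stronger inhibition), for the measured compounds:
compound 1 `COc1ncc(-c2ccc3c(c2)N(c2ccc(F)cc2)C(=O)CO3)cc1NS(=O)(=O)c1ccc(F)cc1` gives > 40000 nM (a limit of the assay)
compound 2 `COc1ncc(-c2ccc3c(c2)N(C2CC2)C(=O)CO3)cc1NS(=O)(=O)c1ccc(F)cc1` gives 24300 nM
compound 3 `COc1ccc(N2C(=O)COc3ccc(-c4cnc(OC)c(NS(=O)(=O)c5ccc(F)cc5)c4)cc32)cc1` gives 13400 nM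

For the measured compounds named here, compound 3 (13400 nM) lies within the scatter of compound 2 (24300 nM), and these are the only two numbers. Compound 1 stands only at a limit (> 40000 nM).

Compound 4 `COc1ncc(-c2ccc3c(c2)N(c2ccc(Cl)cc2)C(=O)CO3)cc1NS(=O)(=O)c1ccc(F)cc1` carries chloro in place of methoxy on an aromatic carbon. The step bearing most directly is methoxy in place of fluoro (an at least 2.9-fold lower number from compound 1 to compound 3 (0.47 log units; beyond the scatter)), whose size is only a floor. The step with the cyclopropyl partner (a 1.8-fold lower number from compound 2 to compound 3 (0.26 log units; within the scatter)) adds little. Losing the methoxy is therefore expected to give a higher number, by a modest amount (a 2.1-fold higher number from compound 3 to compound 4 (0.32 log units; beyond the scatter)). Compound 4 is estimated at 28000 nM (range 14000 nM to 55000 nM). A reading at the limit of the assay is also possible.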

Compound 4, half-maximal inhibitory concentration: 19200 nM
Compound 4: middle estimate off by 1.5-fold (0.16 log units), on the high side; the range from low to high includes it.
By their numbers in this assay, from the lowest: compounds 3, 4 and 2 (each within the scatter of the next). At a limit, above all of these: compound 1.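

Chloro and methoxy on this aromatic carbon are not separated in this assay (a 1.4-fold higher number from compound 3 to compound 4 (0.16 log units; within the scatter)), so the hydrogen-bond acceptor that leaves with the methoxy is not shown to matter here. The 4-chlorophenyl and cyclopropyl groups on the amide-type nitrogen are not separated either (a 1.3-fold lower number from compound 2 to compound 4 (0.10 log units; within the scatter)). Chloro in place of fluoro is the one new step beyond the scatter (an at least 2.0-fold lower number from compound 1 to compound 4 (0.31 log units; beyond the scatter)), and its size is only a floor: the limit of > 40000 nM in this assay, at which 1 of the 4 values shown sits.

Open, going by these compounds, is whether an amine or a carboxylic acid on this aromatic carbon would move the number beyond the scatter of compound 3 and compound 4.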